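A Piperidine Substituent Change in a Channel Antagonist Series

The source may report more compounds than this note shows. Statements on the series, on what has been measured and on what is new or still open speak of the compounds shown alone.

Of the compounds shown here, three sharing a common core have been measured in a functional assay on CHO-K1 cells for antagonist activity at transient receptor potential cation channel subfamily V member 1 (Homo sapiens), read by FLIPR; on this read-out lower numbers stand for stronger inhibition and higher numbers for weaker inhibition. Compound 1 `CCCCNc1nc(C(F)(F)F)ccc1CNC(=O)C(C)c1ccc(NS(C)(=O)=O)c(F)c1` gives 293 nM. Compound 2 `CCCN(CCC)c1nc(C(F)(F)F)ccc1CNC(=O)C(C)c1ccc(NS(C)(=O)=O)c(F)c1` gives 14.7 nM, and compound 3 `COC1CCN(c2nc(C(F)(F)F)ccc2CNC(=O)C(C)c2ccc(NS(C)(=O)=O)c(F)c2)CC1` gives 280 nM. Among these three, compound 3 stands second highest; its number and that of compound 1 lie within the scatter of one another, while compound 2 lies well apart, as a 19-fold higher number from compound 2 to compound 3 (1.28 log units; beyond the scatter) shows. The two steps from compound 1, a 20-fold lower number from compound 1 to compound 2 (1.30 log units; beyond the scatter) and a 1.0-fold lower number from compound 1 to compound 3 (0.02 log units; within the scatter), both exchange the entire group attached to the aromatic carbon.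

Compound 4 `CC(C(=O)NCc1ccc(C(F)(F)F)nc1N1CCC(CN(C)C)CC1)c1ccc(NS(C)(=O)=O)c(F)c1` keeps the piperidine attachment of compound 3 and alters only what sits on it: (dimethylamino)methyl in place of methoxy on a saturated ring carbon. Within the data shown here, none of the measured steps touches the piperidine ring itself; each replaces the whole group on the aromatic carbon, and only the step to dipropylamino moved the number beyond the scatter. With nothing measured that bears on a change within the piperidine ring, the account expects a step that stays within the scatter in this assay, a 1.1-fold lower number from compound 3 to compound 4 (0.05 log units; within the scatter). Compound 4 is therefore estimated at 250 nM, with a broad range from 60 nM to 1000 nM to reflect that uncertainty.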

Compound 4, half-maximal inhibitory concentration: 426 nM
Compound 4: the middle estimate sits 1.7-fold (0.23 log units) below what was measured; measured number inside the range.
By their numbers in this assay, from the lowest: compound 2; then compounds 3, 1 and 4 (each within the scatter of the next).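

Among these compounds, the exchange of methoxy for (dimethylamino)methyl on a saturated ring carbon, three ring bonds from the ring nitrogen, is the first change in this set made on the piperidine itself, and in this assay it gives a 1.5-fold higher number from compound 3 to compound 4 (0.18 log units; within the scatter) as a step that stays within the scatter. The new group thus leaves compound 4 with compound 3 and compound 1: a 1.5-fold higher number from compound 1 to compound 4 (0.16 log units; within the scatter) is also within the scatter, whereas a 29-fold higher number from compound 2 to compound 4 (1.46 log units; beyond the scatter) lies beyond it and keeps compound 2, with its dipropylamino group, well apart from the piperidine compounds. No measurement shown here bears on what lies behind this result.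

What the compounds leave open is whether a larger departure at this ring carbon, such as a carboxylic acid, a hydroxyl or a longer chain ending in an amine, would also stay within the scatter, or whether the piperidine with no group there at all would sit with compound 3 and compound 4. Also open, as far as these compounds go, is whether other open-chain amines on the aromatic carbon, such as diethylamino or dibutylamino, would come close to compound 2 or to the rest.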